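The source may report more compounds than this note shows. Statements on the series, on what has been measured and on what is new or still open speak of the compounds shown alone.

Within the data shown here, in a functional assay on K562 cells (Homo sapiens) for cytotoxicity, read by trypan blue exclusion, with a stated time of 96 h (a lower number here means a stronger inhibitor, a higher number a weaker inhibitor), compound 1 `COc1cc(OC)c(/C=C/S(=O)(=O)Cc2ccc(OC)c(N)c2)c(OC)c1` gives 2.5 nM, the lowest number of the three measured so far. Compound 3 `COc1cc(OC)c(/C=C/S(=O)(=O)Cc2ccc(Cl)c(N)c2)c(OC)c1` gives 10 nM, and compound 2 `COc1cc(OC)c(/C=C/S(=O)(=O)Cc2ccc(Br)c(N)c2)c(OC)c1` gives 750 nM. Compound 4 `COC(=O)C(Nc1cc(CS(=O)(=O)/C=C/c2c(OC)cc(OC)cc2OC)ccc1OC)c1ccc(Cl)cc1` differs from compound 1 by one change: (4-chlorophenyl)(methoxycarbonyl)methyl in place of hydrogen on a nitrogen on an aromatic ring. Among the measured compounds shown here, no measured step touches that nitrogen, so the evidence is only indirect. On an aromatic carbon, swapping methoxy for chloro gave a 4.0-fold higher number from compound 1 to compound 3 (0.60 log units; beyond the scatter), swapping it for bromo gave a 300-fold higher number from compound 1 to compound 2 (2.48 log units; beyond the scatter), and chloro in place of bromo gave a 75-fold lower number from compound 2 to compound 3 (1.88 log units; beyond the scatter). Single changes can therefore move these numbers modestly or greatly. A moderate to large rise is expected, with an estimated step of a 20-fold higher number from compound 1 to compound 4 (1.30 log units; beyond the scatter). For compound 4 the expected value is 50 nM, within a range of 5 nM to 500 nM.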

Compound 4, half-maximal inhibitory concentration: 200 nM
Estimate against measurement, compound 4: 4.0-fold (0.60 log units) below; the range from low to high includes it.
By their numbers in this assay, from the lowest: compound 1; then compound 3; then compound 4; then compound 2.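

Among these compounds, the earlier steps all changed the group on an aromatic carbon, whereas compound 4 is the first to change the nitrogen on an aromatic ring. In this assay putting (4-chlorophenyl)(methoxycarbonyl)methyl in place of hydrogen there gives an 80-fold higher number from compound 1 to compound 4 (1.90 log units; beyond the scatter) and so shows that this nitrogen is also sensitive to substitution, at least with this group. No measurement available here explains the rise. Going by these compounds, whether a methyl group on that nitrogen would cost as much remains open, as does whether the methoxycarbonyl or the 4-chlorophenyl part matters more.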